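A Second Chloro on the Core of Compound 2

A few compounds are considered here, and "the series" means these few. Any claim that something is new, unique, unknown or untested is made for them only; others in the source may bear on it.

compound 1, `ClCc1cccc(Cn2cnc3ncnc(Cl)c32)c1`: 4670 nM
compound 2, `ClCc1cccc(Cn2cnc3c(Cl)ncnc32)c1`: 2290 nM
compound 3, `ClCc1ccc(Cn2cnc3nc(Cl)nc(Cl)c32)cc1`: 2450 nM

Of the compounds shown here, three have been measured in a functional assay on SK-MEL-5 cells (Homo sapiens) for cytotoxicity, read by sulforhodamine B assay, with a stated time of 48 h (a higher number here means a weaker inhibitor of growth, a lower number a stronger inhibitor of growth), and compound 2 gives 2290 nM, the lowest of the three numbers. Compound 3 gives 2450 nM, a number within the scatter of that of compound 2, so the two cannot be ordered. Compound 1 gives 4670 nM, which lies beyond the scatter and marks compound 1 as the weaker grower inhibitor of the pair with compound 2.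

Compound 4, `ClCc1cccc(Cn2cnc3c(Cl)nc(Cl)nc32)c1`, is the next compound. It differs from compound 2 by chloro in place of hydrogen on an aromatic carbon. Within the data shown here, no pair of measured compounds differs in this one place alone, so the size of the effect cannot be read off the measured set. Compound 3 carries two chloro groups on its core as well, though on a different core and with a different benzyl group, and its number sits close to that of compound 2. On that basis the step is expected to be a 1.1-fold lower number from compound 2 to compound 4 (0.06 log units; within the scatter), that is, no change beyond the scatter in this assay. Compound 4 is therefore estimated at 2000 nM, with a range from 900 nM to 5000 nM.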

Compound 4, concentration for 50% growth inhibition: 1580 nM
Compound 4: the middle estimate sits 1.3-fold (0.10 log units) above what was measured; measured number inside the range.
By their numbers in this assay, from the lowest: compounds 4, 2, 3 and 1 (each within the scatter of the next, the first and the last beyond it).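

The change of chloro in place of hydrogen, on the aromatic carbon between two ring nitrogen atoms, gives a 1.4-fold lower number from compound 2 to compound 4 (0.16 log units; within the scatter) in this assay, and this is the first pair among the compounds shown that differs in one place alone. Among these compounds, it shows directly that this position of the core of compound 2 can carry a chloro group with no change in growth inhibition that stands out from the scatter, so compound 2 and compound 4 cannot be ordered, and the earlier compounds could only hint at this through compound 3, which differs in more than one place. Nothing measured here speaks to why the second chloro group leaves the number within the scatter.

Among the compounds shown here, what an amine, a methoxy group or a longer chain such as a butylamino group would do at this same position stays open, as the only group seen there so far is chloro. Also open, going by these compounds, is whether the same change would give a similar step on the core of compound 1 or with the benzyl group of compound 3.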